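From 3-Fluorophenyl to 4-Methoxyphenyl on an Amide

This account rests on a few compounds, and the source may have more. Where it says the series, first, only, none or still open, it means among the compounds named here.

- compound 1 `COc1cc(NC(=O)/C=C/c2cccc(OCc3ccccc3)c2)cc(OC)c1OC` gives 17300 nM
- compound 2 `C=C(Br)C(=O)Nc1cccc(/C=C/C(=O)Nc2cccc(F)c2)c1` gives 26000 nM

In a functional assay on CCRF-CEM cells (Homo sapiens) for inhibition, read by MTT assay, with a stated time of 72 h (on this read-out higher numbers stand for weaker inhibition and lower numbers for stronger inhibition), compound 2 stands at 26000 nM and compound 1 at 17300 nM and, as these two values lie within the usual scatter of each other, they cannot be ranked. Compound 3 `C=C(Br)C(=O)Nc1cccc(/C=C/C(=O)Nc2ccc(OC)cc2)c1` keeps the rest of compound 2 but carries 4-methoxyphenyl in place of 3-fluorophenyl on an amide-type nitrogen. For the measured compounds named here, no measured pair shows this swap, so the expected change, a 1.6-fold lower number from compound 2 to compound 3 (0.21 log units; within the scatter) in this assay, is none beyond the scatter. Compound 3 is estimated at 16000 nM (expected range 3500 nM to 60000 nM).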

Compound 3, half-maximal inhibitory concentration: 26 nM
The estimate for compound 3 lay 620-fold (2.79 log units) above the measured number, and the stated range ends above it.
By their numbers in this assay, from the lowest: compound 3; then compounds 1 and 2 (each within the scatter of the next).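

At the amide-type nitrogen, the group carried there can decide nearly everything in this assay: 4-methoxyphenyl in place of 3-fluorophenyl gives a 1000-fold lower number from compound 2 to compound 3 (3.00 log units; beyond the scatter), a large step for a change in one place. For the compounds shown here, no earlier compound showed that this position could move the number so far. Nothing at hand explains why this swap acts so strongly.

Going by these compounds, it remains open whether the methoxy group, the fluorine or the place of each on the ring accounts for the step. 4-Fluorophenyl or 3-methoxyphenyl on the same nitrogen would begin to separate these, and whether 4-aminophenyl behaves like 4-methoxyphenyl is equally unknown.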